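This account rests on a few compounds, and the source may have more. Where it says the series, first, only, none or still open, it means among the compounds named here.

Three compounds that share one core differ only in the group carried on an amine nitrogen at the far end of the molecule. Compound 1 `O=S(=O)(NCC1CCN(CCCc2c[nH]c3ccc(-n4cnnc4)cc23)CC1)c1ccccc1` bears a phenylsulfonyl there and, in an assay on CHO cells for displacement of a labelled ligand from 5-hydroxytryptamine receptor 1B (Homo sapiens) (a higher number here means a weaker inhibitor, a lower number a stronger inhibitor), compound 1 gives 60 nM. Compound 2 `c1ccc(CNCC2CCN(CCCc3c[nH]c4ccc(-n5cnnc5)cc34)CC2)cc1` bears a benzyl, and in this assay compound 2 gives 28 nM. Compound 3 `C[C@H](NCC1CCN(CCCc2c[nH]c3ccc(-n4cnnc4)cc23)CC1)c1ccccc1` bears a 1-phenylethyl, and in this assay compound 3 gives 58 nM, which places it second highest of the three numbers, level with compound 1 and apart from compound 2. The measured steps show a 2.1-fold lower number from compound 1 to compound 2 (0.33 log units; beyond the scatter), a 1.0-fold lower number from compound 1 to compound 3 (0.01 log units; within the scatter) and a 2.1-fold higher number from compound 2 to compound 3 (0.32 log units; beyond the scatter).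

Compound 4 `CC(=O)Nc1ccc(CNCC2CCN(CCCc3c[nH]c4ccc(-n5cnnc5)cc34)CC2)cc1` is not yet measured. It changes compound 3 by 4-acetamidobenzyl in place of 1-phenylethyl on an amine nitrogen. Two parts of this change can be separated. Going by the values given here, removing the methyl returns the group to a benzyl, and the only precedent is the step from compound 2 to compound 3, which went the other way by a modest amount; reversing it would be expected to lower the number by about as much. Adding the acetamido group has no precedent among these compounds, so its effect is unknown. On balance compound 4 is expected to show a 1.9-fold lower number from compound 3 to compound 4 (0.29 log units; within the scatter), landing near compound 2, with an estimate of 30 nM and a range from 10 nM to 90 nM.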

Compound 4, half-maximal inhibitory concentration: 8.9 nM
For compound 4 the middle estimate is 3.4-fold (0.53 log units) above the measured one, outside the stated range (below it).
By their numbers in this assay, from the lowest: compound 4; then compound 2; then compounds 3 and 1 (each within the scatter of the next).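

The cleanest reading comes from adding a single group to the ring of the benzyl, which gives a 3.1-fold lower number from compound 2 to compound 4 (0.50 log units; beyond the scatter) in this assay with nothing else altered. Going by these compounds alone, until now only the group on the amine nitrogen as a whole had been exchanged, so this is the first sign that the number also responds to a substituent on that group's aromatic ring, and the response is a gain in strength rather than a loss. Exchanging the whole group gives larger steps, a 6.5-fold lower number from compound 3 to compound 4 (0.81 log units; beyond the scatter) and a 6.7-fold lower number from compound 1 to compound 4 (0.83 log units; beyond the scatter), which leave compound 4 with the lowest number of the four; the first of these also removes the methyl and so mixes two changes, while the second also replaces the sulfonyl link. Nothing available explains why the acetamido group has this effect.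

From the compounds shown here alone, whether the amide itself matters remains open, since a methoxy, an amine or a carboxylic acid in place of the acetamido would separate the amide from a substituent of any kind. Going by these compounds, it is also open whether acetamido would lower the number on the 1-phenylethyl group as it does on the benzyl.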